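A few compounds are considered here, and "the series" means these few. Any claim that something is new, unique, unknown or untested is made for them only; others in the source may bear on it.

Measured so far in a physicochemical assay for solubility, with a stated time of 18 h, at pH 7.4; a higher number here means a more soluble compound, a lower number a less soluble compound:
compound 1 `COc1cccc(CNCCCNc2ccnc3cc(CCC(C)C)ccc23)c1O` gives 4200 nM;
compound 2 `COc1cccc(CNCCCNc2ccnc3cc(Cc4cccc(C(F)(F)F)c4)ccc23)c1O` gives 4200 nM;
compound 3 `COc1ccc(F)cc1CNCCCNc1ccnc2cc(Cc3cccc(C(F)(F)F)c3)ccc12` gives 4200 nM.

The three values sit level with one another. Compound 2 and compound 3 share a core and differ as 5-fluoro-2-methoxyphenyl in place of 2-hydroxy-3-methoxyphenyl on a saturated chain carbon bound to an amine nitrogen; the step of no change at the digits printed from compound 2 to compound 3 (within the scatter). The change from compound 2 to compound 1 is isobutyl in place of 3-(trifluoromethyl)phenyl on a saturated chain carbon bound to an aromatic carbon, and its step of no change at the digits printed from compound 2 to compound 1 (within the scatter).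

Compound 4 `COc1ccc(F)cc1CNCCCNc1ccnc2cc(CCC(C)C)ccc12` is not yet measured. It arises from compound 3 by isobutyl in place of 3-(trifluoromethyl)phenyl on a saturated chain carbon bound to an aromatic carbon, the same change as from compound 2 to compound 1, made at the same place. Because no change at the digits printed from compound 2 to compound 1 (within the scatter), the step is expected to be no change at the digits printed from compound 3 to compound 4 (within the scatter). On that basis compound 4 is estimated at 4200 nM in this assay, with a range from 2100 nM to 8400 nM.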

Compound 4, solubility: 4200 nM
Estimate against measurement, compound 4: no gap at the digits printed; the range from low to high includes it.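

In this assay the isobutyl change repeats on the second core as no change at the digits printed from compound 3 to compound 4 (within the scatter), and the change on the other side of the molecule reads no change at the digits printed from compound 1 to compound 4 (within the scatter), so all four compounds close a square with no step beyond the scatter. This shows that the change carries between these two cores as a flat step, in this one pair only; it does not show that a step of real size would carry from one core to another, as none occurs here. Nothing at hand gives a measured reason for the flat values.

Open, going by these compounds, is whether the reading stays flat with a carboxylic acid, an amine or a chain longer than isopentyl on a saturated chain carbon bound to an aromatic carbon. Also open, on these data alone, is whether the isobutyl change stays flat on any further core.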